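Pyridin-4-yl for pyridin-3-yl in a cytotoxicity series

The source may hold more compounds than are shown below. What is called first, only, known or untested is meant among the compounds shown, and "the series" means these compounds.

compound 1 `O=C(c1cn(-c2ccccc2)nc1-c1cccnc1)N1CCC(Cc2ccccc2)CC1`: in a functional assay on MDA-MB-231 cells (Homo sapiens) for cytotoxicity, read by MTT assay, with a stated time of 48 h (on this read-out higher numbers stand for weaker inhibition and lower numbers for stronger inhibition), compound 1 gives > 100000 nM, a limit of the assay
compound 2 `CC(C)c1cccc(OC(=O)c2cn(-c3ccccc3)nc2-c2cccnc2)c1`: in this assay compound 2 gives > 100000 nM, also a limit

On the numbers shown, compound 1 stands only at a limit; no number places it against compound 2, whose value is likewise a limit, so neither can be ranked (the limit of > 100000 nM in this assay, at which 2 of the 2 values shown sit). Compound 3 `O=C(c1cn(-c2ccccc2)nc1-c1ccncc1)N1CCC(Cc2ccccc2)CC1` differs from compound 1 by pyridin-4-yl in place of pyridin-3-yl on an aromatic carbon, a pyridin-4-yl in place of pyridin-3-yl on an aromatic carbon. For the measured compounds named here, no measured step of this kind exists, so the size of the step from compound 1 to compound 3 in this assay is not read from data; the expectation is no change beyond the scatter, with compound 3 most likely reported again as a limit. Compound 3 is estimated at 150000 nM, between 50000 nM and 500000 nM, which is an expected step that the limit leaves unreadable from compound 1 to compound 3.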

Compound 3, half-maximal inhibitory concentration: > 100000 nM
Compound 3: a limit, no number; the forecaster's own chance of this, stated with the estimate: 85%; the middle value is on the limit's open side.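

In this assay compound 3 gives > 100000 nM, a limit and not a number. For the compounds shown here, compound 1 also stands at a limit, so no step between compound 1 and compound 3 can be read. The compounds shown leave open whether pyridin-4-yl in place of pyridin-3-yl changes cytotoxicity at all: the limit of > 100000 nM in this assay, at which 3 of the 3 values shown sit.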